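Moving the ring chlorine in a cathepsin S nitrile series

This account rests on a few compounds, and the source may have more. Where it says the series, first, only, none or still open, it means among the compounds named here.

Measured compounds in an assay for inhibition of cathepsin S (Homo sapiens); on this read-out lower numbers stand for stronger inhibition and higher numbers for weaker inhibition:
compound 1, `CC(C)C[C@H](NC(=O)N1CCOCC1)C(=O)N[C@H](C#N)CCc1ccccc1`: 47 nM
compound 2, `CC(C)C[C@H](NC(=O)N1CCOCC1)C(=O)N[C@H](C#N)C(C)(C)C`: 107000 nM
compound 3, `CC(C)C[C@H](NC(=O)N1CCOCC1)C(=O)N[C@H](C#N)COCc1ccccc1Cl`: 9 nM

Compound 3 gives the lowest number of the three in this assay. Its nearest neighbour is compound 1, with a 5.2-fold lower number from compound 1 to compound 3 (0.72 log units; beyond the scatter); compound 2 lies furthest away, with a 12000-fold lower number from compound 2 to compound 3 (4.08 log units; beyond the scatter). Compound 4, `CC(C)C[C@H](NC(=O)N1CCOCC1)C(=O)N[C@H](C#N)COCc1ccc(Cl)cc1`, keeps every atom of compound 3 and differs only in how they are joined: 4-chlorophenyl in place of 2-chlorophenyl on a saturated chain carbon bound to an oxygen on a saturated carbon.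

Going by the values given here, none of the measured steps alters the chlorophenyl ring alone. The two steps that bear at all on this part of the molecule, a 2300-fold higher number from compound 1 to compound 2 (3.36 log units; beyond the scatter) and a 5.2-fold lower number from compound 1 to compound 3 (0.72 log units; beyond the scatter), exchange the whole side group rather than shifting a single substituent, so they set only a loose frame. On that basis compound 4 is expected to stay close to compound 3, with a step of a 1.7-fold higher number from compound 3 to compound 4 (0.22 log units; within the scatter) expected in this assay, which may well fall within the scatter. The estimate for compound 4 is therefore 15 nM, with a range from 5 nM to 50 nM expected.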

Compound 4, half-maximal inhibitory concentration: 27 nM
Beside the measured number, compound 4's estimate is 1.8-fold (0.26 log units) below it; the range from low to high includes it.
By their numbers in this assay, from the lowest: compound 3; then compounds 4 and 1 (each within the scatter of the next); then compound 2.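

In this assay, going by these compounds alone, the place of the chlorine on the ring matters by itself: 2-chlorophenyl to 4-chlorophenyl gives a 3.0-fold higher number from compound 3 to compound 4 (0.48 log units; beyond the scatter) and is the only step here that alters this ring alone. The 4-chlorophenyl side group stays far from the tert-butyl one, with a 4000-fold lower number from compound 2 to compound 4 (3.60 log units; beyond the scatter) in this assay, so most of the distance from that group survives the move. Against the phenethyl side group the step is a 1.7-fold lower number from compound 1 to compound 4 (0.24 log units; within the scatter) while the 2-chlorophenyl compound stands clear of it with a 5.2-fold lower number from compound 1 to compound 3 (0.72 log units; beyond the scatter) and no evidence is available on what lies behind the difference between the two ring placements.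

Still open, as far as these compounds go, is whether this difference belongs to chlorine or would recur with an amine or a carboxylic acid on the ring in its place. Also open, from the compounds shown here alone, is how the plain benzyloxy group, with no chlorine, would compare with both chlorinated groups.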